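This account rests on a few compounds, and the source may have more. Where it says the series, first, only, none or still open, it means among the compounds named here.

Measured so far in a functional assay on HeLa cells (Homo sapiens) for antiproliferative activity, read by MTT assay; a lower number here means a stronger inhibitor, a higher number a weaker inhibitor:
- compound 1 `CN1CCN(c2ccc(Nc3ncc(/N=C/c4ccccc4)c(NC4CCCC4)n3)cc2)CC1`: > 100000 nM
- compound 2 `NS(=O)(=O)c1ccc(Nc2ncc(/N=C/c3ccccc3)c(NC3CCCC3)n2)cc1`: 15600 nM
- compound 3 `CCOC(=O)/C=N/c1cnc(Nc2ccc(N3CCN(C)CC3)cc2)nc1NC(C)C`: 11500 nM

The value of compound 1 in this assay is a limit of the assay, not a number; one of the three values shown sits at the limit of > 100000 nM in this assay, at which 1 of the 3 values shown sits. From compound 1 to compound 2 the change is sulfamoyl in place of 4-methylpiperazin-1-yl on an aromatic carbon, and it gives an at least 6.4-fold lower number from compound 1 to compound 2 (0.80 log units; beyond the scatter). Compound 3 and compound 2 give numbers that lie within the scatter of each other in this assay. The difference between the core of compound 1 and the core of compound 3 is not broken down here.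

Compound 4 `CCOC(=O)/C=N/c1cnc(Nc2ccc(S(N)(=O)=O)cc2)nc1NC(C)C` is not yet measured. Relative to compound 3 it carries sulfamoyl in place of 4-methylpiperazin-1-yl on an aromatic carbon, the same change as that from compound 1 to compound 2. For compound 4 the step expected is a 4.6-fold lower number from compound 3 to compound 4 (0.66 log units; beyond the scatter), an expectation that rests on compound 1 and compound 2 and their step of an at least 6.4-fold lower number from compound 1 to compound 2 (0.80 log units; beyond the scatter), with the note that the value of compound 1 is a limit, so the true step there may be larger than shown. Compound 4 is therefore estimated at 2500 nM in this assay, with a range of 600 nM to 8000 nM.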

Compound 4, half-maximal inhibitory concentration: 83300 nM
Estimate against measurement, compound 4: 33-fold (1.52 log units) below; the whole stated range lies below it.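

In this assay, sulfamoyl in place of 4-methylpiperazin-1-yl on an aromatic carbon gives a 7.2-fold higher number from compound 3 to compound 4 (0.86 log units; beyond the scatter), so the earlier step does not carry over from the core of compound 1 to the core of compound 3, and its direction is reversed: the same change on two cores in this assay, an at least 6.4-fold lower number (0.80 log units; beyond the scatter) from compound 1 to compound 2 and a 7.2-fold higher number (0.86 log units; beyond the scatter) from compound 3 to compound 4, at least 46-fold (1.66 log units) apart, beyond the scatter of two such steps. The value of compound 1 is a limit of the assay, not a number: the limit of > 100000 nM in this assay, at which 1 of the 4 values shown sits. These two pairs do not show which part of the difference between the two cores goes with the reversal, and they give no rule for any other core in the series.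

Among these compounds, open is whether a compound with only one part of the core of compound 3 changed would follow compound 2 or compound 4, for example one with a carboxylic acid or an amide in place of the ethyl ester. Also open, going by these compounds, is how a morpholine or a simple amine in place of 4-methylpiperazin-1-yl would behave on each of the two cores.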